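Trading the benzyl ester for a cyanomethyl ester

A few compounds are considered here, and "the series" means these few. Any claim that something is new, unique, unknown or untested is made for them only; others in the source may bear on it.

In an ADME assay on MCF7 cells (Homo sapiens) for cytotoxicity, read by CellTiter-Glo, with a stated time of 24 h (a higher number here means a weaker inhibitor of growth, a lower number a stronger inhibitor of growth), compound 2 `CC1=C(C(=O)OCc2ccccc2)C(c2ccc(Cl)cc2Cl)NC(=O)N1CCCC(=O)OCc1ccccc1` gives > 100000 nM as a limit, not a number. Compound 1 `CC1=C(C(=O)OCc2ccccc2)C(c2ccc(Cl)cc2Cl)NC(=O)N1CCCCC(=O)O` gives > 100000 nM as a limit too. Compound 3 `CC1=C(C(=O)OCc2ccccc2)C(c2ccc(Cl)cc2Cl)NC(=O)N1CCCC(=O)OCc1ccccc1F` also gives > 100000 nM as a limit. The measured compounds thus all stand at the limit of > 100000 nM in this assay, at which 3 of the 3 values shown sit, and none of them offers an exact starting point.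

Compound 4 `CC1=C(C(=O)OCc2ccccc2)C(c2ccc(Cl)cc2Cl)NC(=O)N1CCCC(=O)OCC#N` differs from compound 2 by cyano in place of phenyl on a saturated chain carbon bound to an oxygen next to a carbonyl group and so carries cyanomethoxycarbonyl in place of benzyloxycarbonyl. The closest measured change is a step that the two limits leave unreadable from compound 2 to compound 3 on that same benzyl group. Changes at the end of the chain are a step that the two limits leave unreadable from compound 1 to compound 2 and a step that the two limits leave unreadable from compound 1 to compound 3 in the same way. None of these steps gives a size or a direction, so no step beyond the scatter is expected in this assay here.

The expected change is a step that the limit leaves unreadable from compound 2 to compound 4 and it carries no firm direction. For compound 4 the estimated value is 120000 nM with an expected range from 40000 nM to 300000 nM and a good chance of another limit.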

Compound 4, concentration for 50% growth inhibition: > 100000 nM
Compound 4 ended at the assay's limit; the forecaster's own chance of this, stated with the estimate: 80%; the middle value lies beyond the limit too.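

Compound 4 sits at a limit, as do compound 1, compound 2 and compound 3, so no step among these compounds can be read in size or direction: the limit of > 100000 nM in this assay, at which 4 of the 4 values shown sit. On these data alone, how strongly any of them inhibits growth, if at all, and whether changing the group at the chain end alters that, stays open.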